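Acyl swap on the ring amine: compound 2 to compound 3

The source may hold more compounds than are shown below. What is called first, only, known or untested is meant among the compounds shown, and "the series" means these compounds.

Among the compounds with values here, compound 2 `CCCCNc1nc(N)nc2c1CN(C(=O)c1scnc1C)CC2` holds the highest number of the two measured so far in an assay on HEK293 cells for agonist activity at Toll-like receptor 8 (Homo sapiens), read by a luciferase reporter, with a stated time of 6 h (on this read-out lower numbers stand for an effect already at smaller amounts and higher numbers for an effect only at larger amounts of compound), at 5.6 uM. Within the data shown here, compound 1 `CCCCNc1nc(N)nc2c1CN(Cc1cccnc1)CC2` gives 0.13 uM; the one measured step, a 43-fold higher number from compound 1 to compound 2 (1.63 log units; beyond the scatter), concerns the group on the ring amine nitrogen, not its ring. Compound 3 `CCCCNc1nc(N)nc2c1CN(C(=O)c1csnn1)CC2` carries 1,2,3-thiadiazol-4-yl in place of 4-methyl-1,3-thiazol-5-yl on a carbonyl carbon. Among the measured compounds shown here, no measured step exchanges one ring for another on this carbonyl carbon, so no step beyond the scatter is expected in this assay. For compound 3 the expected step is no change at the digits printed from compound 2 to compound 3 (within the scatter). For compound 3 the estimate is 5.6 uM, with a range from 2 uM to 16 uM.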

Compound 3, minimum effective concentration: 0.1 uM
Estimate against measurement, compound 3: 56-fold (1.75 log units) above; measured number outside the range, below it.
By their numbers in this assay, from the lowest: compounds 3 and 1 (each within the scatter of the next); then compound 2.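

On the carbonyl carbon, 1,2,3-thiadiazol-4-yl in place of 4-methyl-1,3-thiazol-5-yl gives a 56-fold lower number from compound 2 to compound 3 (1.75 log units; beyond the scatter) in this assay, so the ring on this carbonyl carbon matters greatly. With a 1.3-fold lower number from compound 1 to compound 3 (0.11 log units; within the scatter) as the other new step, the acyl link on the ring amine nitrogen does not by itself carry a high number. No evidence at hand bears on the reason for this step.

The change replaces the ring and removes the methyl group together, so their shares cannot be separated. A 1,3-thiazol-5-yl without the methyl group on this carbonyl carbon would address that question.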